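The compounds below may be only part of what the source reports. "The series", "measured", "known", "first", "only" and "open" are said of these compounds alone.

Of the compounds shown here, three built on one shared core have been tested in a functional assay on the whole organism for inhibition, with Rattus norvegicus as the target, read by paw edema; on this read-out lower numbers stand for an effect already at smaller amounts and higher numbers for an effect only at larger amounts of compound. Compound 1 `O=C(O)c1cc(-c2ncccn2)ccc1O` gives 100 mg/kg, compound 2 `O=C(O)c1cc(-c2cscn2)ccc1O` gives 95 mg/kg, and compound 3 `O=C(O)c1cc(-c2ncco2)ccc1O` gives 100 mg/kg. Compound 2 holds the lowest of these three numbers, yet its gaps to compound 1 and to compound 3 both lie within the scatter, so the three stand level. Within the data shown here, the one directly comparable step, a 1.1-fold higher number from compound 2 to compound 3 (0.02 log units; within the scatter), confirms that exchanging one five-membered ring for another at this position left the dose unchanged.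

Compound 4 `O=C(O)c1cc(-n2cccn2)ccc1O` carries the change (1H-pyrazol-1-yl in place of 1,3-thiazol-4-yl on an aromatic carbon). This is again a swap of one five-membered aromatic ring with two hetero atoms for another, at the same place on the core. The step from compound 2 to compound 3 was within the scatter, and compound 1 and compound 2 show values within the scatter of each other, so no shift beyond the scatter is expected here either. Compound 4 is therefore expected to give about 100 mg/kg, within 50 mg/kg to 200 mg/kg, which means an expected step of a 1.1-fold higher number from compound 2 to compound 4 (0.02 log units; within the scatter).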

Compound 4, dose for half-maximal effect: 200 mg/kg
The estimate for compound 4 lay 2.0-fold (0.30 log units) below the measured number; the range from low to high includes it.
By their numbers in this assay, from the lowest: compounds 2, 1, 3 and 4 (each within the scatter of the next, the first and the last beyond it).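

In this assay, among these compounds, this position proves not entirely indifferent to which five-membered ring it carries: 1H-pyrazol-1-yl in place of 1,3-thiazol-4-yl gives a 2.1-fold higher number from compound 2 to compound 4 (0.32 log units; beyond the scatter) and is the first step here to pass the scatter, though only modestly. The same group in place of 1,3-oxazol-2-yl gives a 2.0-fold higher number from compound 3 to compound 4 (0.30 log units; within the scatter) and so stays within the scatter, which means the separation rests on the comparison with compound 2 alone. The two rings in the first step match in heavy atoms, hydrogen-bond donors and acceptors, so these counts do not separate them, and nothing measured here accounts for the difference. Still open, going by these compounds, is how this position responds to a group other than an aromatic ring, such as an amine or a longer alkyl chain. A plain phenyl ring would show whether ring hetero atoms matter here at all.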